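Trimming a Fluoroethoxy Group to Methoxy

A few compounds are considered here, and "the series" means these few. Any claim that something is new, unique, unknown or untested is made for them only; others in the source may bear on it.

In a functional assay on SW620/5-FU cells (Homo sapiens) for cytotoxicity, read by MTT assay, with a stated time of 48 h, in the presence of a further agent that is not named here (a lower number here means that less compound is needed, a higher number that more compound is needed for the effect), compound 2 `Cn1ncc2c(-c3ccc(F)cc3)cc(NNC(=O)Nc3cc(Cl)nc(OCCF)c3)nc21` gives 29300 nM, a number that lies beyond the scatter from compound 3 but within the scatter of compound 1. Compound 1 `CC(C)c1cc(NNC(=O)Nc2cc(Cl)nc(Cl)c2)nc2c1c(C(F)(F)F)nn2C` gives 19100 nM and compound 3 `Cn1nc(C(F)(F)F)c2c(-c3ccccc3)cc(NNC(=O)Nc3cc(Cl)nc(Cl)c3)nc21` gives 13100 nM; the step of a 1.5-fold lower number from compound 1 to compound 3 (0.16 log units; within the scatter) stayed within the scatter. Compound 4 `COc1cc(NC(=O)NNc2cc(-c3ccc(F)cc3)c3cnn(C)c3n2)cc(Cl)n1` differs from compound 2 only at the ether chain: hydrogen in place of fluoromethyl on a saturated chain carbon bound to an oxygen on an aromatic ring. Among the compounds with values here, no measured step touches this position, so there is no precedent from which to expect a sizeable shift in either direction in this assay. The estimate therefore stays close to compound 2, with the step of a 1.2-fold lower number from compound 2 to compound 4 (0.07 log units; within the scatter) expected to remain within the scatter. Compound 4 is expected to give 25000 nM with a range from 10000 nM to 60000 nM.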

Compound 4, half-maximal effective concentration: 24100 nM
Compound 4: the middle estimate sits 1.0-fold (0.02 log units) above what was measured, within the range that was stated.
By their numbers in this assay, from the lowest: compounds 3, 1, 4 and 2 (each within the scatter of the next, the first and the last beyond it).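

Trimming 2-fluoroethoxy to methoxy is the first change shown at this position, and in this assay the step is a 1.2-fold lower number from compound 2 to compound 4 (0.08 log units; within the scatter). With this core, then, the fluoromethyl end of the ether chain can give way to hydrogen without a change that stands out from the scatter. Nothing measured here offers an explanation for this result.

Going by these compounds, whether a longer chain or an amine at this position would also stay within the scatter remains open. So does whether the same trim would behave alike on the core of compound 3 .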